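This account rests on a few compounds, and the source may have more. Where it says the series, first, only, none or still open, it means among the compounds named here.

Measured compounds:
compound 1 `CCC(C(=O)N1CCN(c2ccccc2F)CC1)N1C(=O)CCC1=O` — 0%
compound 2 `COc1cccc(N2CCN(C(=O)C(C)N3C(=O)CCC3=O)CC2)c1` — 0%

For the measured compounds named here, the two compounds so far share a core and differ in the aryl group on the ring nitrogen and in the chain at the succinimide. In a functional assay on the whole organism (strain Swiss) with Mus musculus as the target, in the maximal electroshock model, with a stated time of 0.5 h, at a dose of 100 mg/kg by the intraperitoneal route (a higher number here means a stronger effect of the compound at the dose given, a lower number a weaker effect), compound 1 gives 0%. Compound 2 stands level with compound 1 at the digits shown: in this assay compound 2 gives 0%, and the two values lie within the scatter of each other, so no order between them can be read.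

Compound 3 `CC(C(=O)N1CCN(c2ccc(Cl)cc2)CC1)N1C(=O)CCC1=O` has not yet been measured. Its difference from compound 2 is 4-chlorophenyl in place of 3-methoxyphenyl on an amine nitrogen in a ring. Going by the values given here, no step between measured compounds is available to show what such an exchange does here, and both measured values sit at the floor of the read-out. Compound 3 is therefore expected to remain near that floor, with a step of a number 10 percentage points higher from compound 2 to compound 3 (within the scatter) that stays within the scatter or barely beyond it. The estimate for compound 3 in this assay is 10%, with a range from 0% to 40%.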

Compound 3, a percentage reported as activity, at one dose (the size of the read-out at that dose, not a potency): 25%
Compound 3: the middle estimate sits 15 percentage points below what was measured, within the range that was stated.
By their numbers in this assay, from the lowest: compounds 1 and 2 (each within the scatter of the next); then compound 3.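

With 4-chlorophenyl in place of 3-methoxyphenyl on an amine nitrogen in a ring, this assay shows a number 25 percentage points higher from compound 2 to compound 3 (beyond the scatter) and so gives the first read-out above the floor. This shows that the group at this position can change the effect at the dose given, which the two earlier compounds, level with each other, could not show. The exchange alters both the substituent and its place on the aromatic ring, so the step cannot be assigned to either alone, and nothing shown accounts for it.

On these data alone, whether 3-chlorophenyl or 4-methoxyphenyl would separate the substituent from its place remains open. So does whether the step would hold with a plain phenyl for comparison or with a longer chain at the succinimide.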